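Bromo for butyl on the aryl urea of compound 3

The compounds below may be only part of what the source reports. "The series", "measured", "known", "first", "only" and "open" are said of these compounds alone.

Compound 1 `CC(C)c1ccc(NC(=O)N2CCN(c3ncccc3Br)CC2)cc1`: 27.1 nM
Compound 2 `CCc1cccnc1N1CCN(C(=O)Nc2ccc(C(C)C)cc2)CC1`: 828 nM
Compound 3 `CCCCc1ccc(NC(=O)N2CCN(c3ncccc3Cl)CC2)cc1`: 203 nM

In a functional assay on HEK293 cells for antagonist activity at transient receptor potential cation channel subfamily V member 1 (Rattus norvegicus) (a lower number here means a stronger inhibitor, a higher number a weaker inhibitor), compound 3 `CCCCc1ccc(NC(=O)N2CCN(c3ncccc3Cl)CC2)cc1` gives 203 nM, the second highest of the three numbers, sitting beyond the scatter from both compound 1 and compound 2. Compound 4 `O=C(Nc1ccc(Br)cc1)N1CCN(c2ncccc2Cl)CC1` differs from compound 3 by bromo in place of butyl on an aromatic carbon. Among the compounds with values here, none of the measured steps touches this ring; the only step in hand, a 31-fold higher number from compound 1 to compound 2 (1.49 log units; beyond the scatter), concerns the other ring and cannot be carried over. With nothing directly bearing on the change, the author expects compound 4 to stay near compound 3 in this assay, with a 1.2-fold higher number from compound 3 to compound 4 (0.09 log units; within the scatter) and wide uncertainty. For compound 4 the estimate is 250 nM, between 60 nM and 1000 nM.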

Compound 4, half-maximal inhibitory concentration: 1010 nM
The estimate for compound 4 lay 4.0-fold (0.61 log units) below the measured number; measured number outside the range, above it.
By their numbers in this assay, from the lowest: compound 1; then compound 3; then compounds 2 and 4 (each within the scatter of the next).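

In this assay, the substituent on this aromatic carbon matters: bromo in place of butyl gives a 5.0-fold higher number from compound 3 to compound 4 (0.70 log units; beyond the scatter) and so shows a change on this ring moving the number beyond the scatter, which the earlier step, confined to the other ring, could not show. Within the data shown here, a four-carbon chain and a single bromine atom are the only pair compared at this place, so this step alone fixes no trend there. No available evidence accounts for the weaker inhibition.

On these data alone, whether the shift follows the loss of butyl or the arrival of bromo remains open. A propyl chain, a methoxy group or a fluorine atom on this carbon could help separate the two.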